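This account rests on a few compounds, and the source may have more. Where it says the series, first, only, none or still open, it means among the compounds named here.

Compound 1 `Cc1nc(-c2ccc(Cl)cc2)sc1C1SCC(=O)N1c1ccc(F)c(Cl)c1`: 45.2%
Compound 2 `Cc1nc(-c2ccc(Cl)cc2)sc1C1SCC(=O)N1c1ccc(F)cc1`: 63.9%

Both numbers come from a functional assay on the whole organism (strain Wistar albino) for inhibition, with Rattus norvegicus as the target, read by paw edema, with stated times of 1 h and 2 h, at a dose of 40 mg/kg by the oral route; a higher number here means more inhibition at the dose given (going by the name of the read-out), a lower number less inhibition. For the measured compounds named here, compound 2 stands highest of the two compounds measured so far, and the only other measured compound, compound 1, sits beyond the scatter below it. Going by the values given here, the single measured step, a number 18.7 percentage points higher from compound 1 to compound 2 (beyond the scatter), describes the removal of a chloro group from an aromatic carbon.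

Compound 3 `Cc1nc(-c2ccc(Cl)cc2)sc1C1SCC(=O)N1c1ccc(Cl)cc1` differs from compound 2 in one place: chloro in place of fluoro on an aromatic carbon. Among the compounds with values here, no measured step swaps one halogen for another, so the step from compound 1 to compound 2 bears on this change only loosely: it shows that taking a chloro group off an aromatic carbon raised inhibition in this assay , which gives a weak hint that putting a chloro group onto an aromatic carbon may not raise it further. Within the data shown here, because a number 18.7 percentage points higher from compound 1 to compound 2 (beyond the scatter) is the only guide and does not match the change closely, the step of a number 7.9 percentage points lower from compound 2 to compound 3 (within the scatter) is expected to stay within the scatter, leaning if anything slightly downward. Compound 3 is therefore estimated at 56%, with a range from 36% to 76%.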

Compound 3, a percentage reported as inhibition, in the whole organism at one dose (the size of the read-out at that dose, not a potency): 45.7%
The estimate for compound 3 lay 10.3 percentage points above the measured number; low and high end bracket the measured number.
By their numbers in this assay, from the lowest: compounds 1 and 3 (each within the scatter of the next); then compound 2.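

Fluoro and chloro are not interchangeable at this place, on an aromatic carbon para to a large group: the swap of fluoro for chloro gives a number 18.2 percentage points lower from compound 2 to compound 3 (beyond the scatter) in this assay. The earlier step removed a chloro from a ring that kept its fluoro, whereas this one changes the group at the para place itself, and the two compounds with a chloro on this ring now stand close together, with a number 0.5 percentage points higher from compound 1 to compound 3 (within the scatter). Among these three compounds, then, the 4-fluorophenyl compound stands alone at the top, while the 4-chlorophenyl and 3-chloro-4-fluorophenyl compounds cannot be told apart, and no compound shown goes against this. Nothing available here accounts for the difference between the two halogens.

The compounds shown leave open how a plain phenyl ring with hydrogen at this place, or a different group there such as a methoxy, an amine or a carboxylic acid, would compare with the 4-fluorophenyl ring. They also leave open whether the same order of fluoro and chloro would hold at other doses, since every number here comes from a single dose.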